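Swapping isoquinolin-4-yl for quinolin-4-yl on the carbonyl

The source may hold more compounds than are shown below. What is called first, only, known or untested is meant among the compounds shown, and "the series" means these compounds.

Measured in an ADME assay on the whole organism (strain ICR) for pharmacokinetics, with Mus musculus as the target, using cassette dosing, at a dose of 1 mg/kg by the oral route; on this read-out lower numbers stand for lower oral bioavailability and higher numbers for higher oral bioavailability:
- compound 1 `Cn1cc(C(=O)N2CCN(C(=O)c3ccc(Br)cn3)[C@@H](c3ccc(Cl)cc3)C2)cc(-c2cccc(C#N)c2)c1=O`: 16.1%
- compound 2 `O=C(c1c[nH]c(=O)c2ccccc12)N1CCN(C(=O)c2ccc(Br)cc2)[C@@H](c2ccc(Cl)cc2)C1`: 9.6%
- compound 3 `O=C(c1cncc2ccccc12)N1CCN(C(=O)c2ccc(Br)cc2)[C@@H](c2ccc(Cl)cc2)C1`: 0.4%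

Compound 3, at 0.4%, cannot be told apart from compound 2, at 9.6%, since the two lie within the scatter of each other. Compound 1, at 16.1%, stands beyond the scatter above compound 3.

The next compound to be measured is compound 4 `O=C(c1ccnc2ccccc12)N1CCN(C(=O)c2ccc(Br)cc2)[C@@H](c2ccc(Cl)cc2)C1`. It carries quinolin-4-yl in place of isoquinolin-4-yl on a carbonyl carbon.

Among the measured compounds shown here, only one measured step bears on this change. It is a number 9.2 percentage points lower from compound 2 to compound 3 (within the scatter), which also falls on that carbonyl carbon but exchanges a different pair of groups. For the measured compounds named here, that step stayed within the scatter, and no measured pair shows the effect of this particular exchange, so the evidence is thin. Compound 1 differs from the others in more than one place and offers no direct guide.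

With compound 3 at 0.4% as the starting point, the expected change is a number 2.6 percentage points higher from compound 3 to compound 4 (within the scatter), which means no step beyond the scatter is expected. For compound 4 the estimated value in this assay is 3%, with an expected range from 0% to 12%.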

Compound 4, oral bioavailability: 19.7%
Beside the measured number, compound 4's estimate is 16.7 percentage points below it; measured number outside the range, above it.
By their numbers in this assay, from the lowest: compounds 3, 2, 1 and 4 (each within the scatter of the next, the first and the last beyond it).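

In this assay, among the compounds shown here, quinolin-4-yl in place of isoquinolin-4-yl on the carbonyl carbon gives a number 19.3 percentage points higher from compound 3 to compound 4 (beyond the scatter) and so yields the first step at this position that stands clear of the scatter for an exchange of two groups with the same atoms, joined differently. The same group set against the group of compound 2, which has one more heavy atom, an oxygen, gives a number 10.1 percentage points higher from compound 2 to compound 4 (beyond the scatter), whereas the earlier step at this carbonyl carbon had stayed within the scatter; the read-out at this position therefore depends on how the group is built, even when its heavy atoms and its counts of donors and acceptors stay the same. Nothing in the data explains why these two closely matched groups read so differently.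

From the compounds shown here alone, it remains open whether quinolin-4-yl would act in the same way on the core of compound 1, which differs from compound 4 in more than one place. Going by these compounds, it also remains open how a naphthalen-1-yl group, which has no ring nitrogen, or a methoxy group added to quinolin-4-yl would read in this assay at this carbonyl carbon.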